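The compounds below may be only part of what the source reports. "The series", "measured", "known", "first", "only" and "open" are said of these compounds alone.

Of the compounds shown here, three built on one shared core have been tested in a functional assay on PC-3 cells (Homo sapiens) for cytotoxicity, read by MTT assay, with a stated time of 48 h; a lower number here means a stronger inhibitor, a higher number a weaker inhibitor. Compound 1 `COc1cc(-c2nnc3n2NC(c2cccs2)C(C(=O)c2ccccc2)S3)cc(OC)c1OC` gives 86300 nM. Compound 2 `COc1cc(-c2nnc3n2NC(c2ccco2)C(C(=O)c2cccc(Br)c2)S3)cc(OC)c1OC` gives 63900 nM in this assay, and compound 3 `COc1cc(-c2nnc3n2NC(c2ccco2)C(C(=O)c2ccccc2C)S3)cc(OC)c1OC` gives 88400 nM in this assay. For the measured compounds named here, on these numbers compound 3 sits within the usual scatter of both companions: its gap to compound 1 is almost nothing, and the one measured step, a 1.4-fold higher number from compound 2 to compound 3 (0.14 log units; within the scatter), likewise stays inside the scatter. That step swapped the aromatic group attached to the carbonyl carbon, and the number barely moved.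

Compound 4 `COc1cc(-c2nnc3n2NC(c2ccco2)C(C(=O)c2ccc([N+](=O)[O-])cc2)S3)cc(OC)c1OC` is the next member and has not yet been measured in this assay. It differs from compound 3 in a single place: 4-nitrophenyl in place of 2-methylphenyl on a carbonyl carbon. Going by the values given here, the only measured step that bears on this change is the one already described, which altered the same carbonyl-bound group and produced no shift beyond the scatter. On that evidence, compound 4 is expected to give a number close to that of compound 3, with no step beyond the scatter in either direction. Compound 4 is therefore estimated at 80000 nM, with a range from 35000 nM to 180000 nM. This estimate implies a 1.1-fold lower number from compound 3 to compound 4 (0.04 log units; within the scatter), which is expected to remain within the scatter.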

Compound 4, half-maximal inhibitory concentration: 27900 nM
Beside the measured number, compound 4's estimate is 2.9-fold (0.46 log units) above it; measured number below the stated range.
By their numbers in this assay, from the lowest: compound 4; then compounds 2, 1 and 3 (each within the scatter of the next).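

In this assay the group on the carbonyl carbon turns out to be able to move the number beyond the scatter: 4-nitrophenyl in place of 2-methylphenyl gives a 3.2-fold lower number from compound 3 to compound 4 (0.50 log units; beyond the scatter) and 4-nitrophenyl in place of 3-bromophenyl gives a 2.3-fold lower number from compound 2 to compound 4 (0.36 log units; beyond the scatter). The earlier change at this same place, a 1.4-fold higher number from compound 2 to compound 3 (0.14 log units; within the scatter), stayed inside the scatter, so the position is not indifferent to what it carries, although both new steps are modest and compound 4 still reads 27900 nM in this assay. No measurement shown gives a reason for this shift.

The three rings on the carbonyl carbon differ both in their substituent and in where it sits, so the compounds shown cannot separate the effect of the nitro group from the effect of its place on the ring. From the compounds shown here alone, it also stays open whether a 4-aminophenyl or 4-methoxyphenyl group at this position would read like 4-nitrophenyl or like the other two groups.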